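Extending the Methylamino Group: From Compound 2 to Compound 4

The compounds below may be only part of what the source reports. "The series", "measured", "known", "first", "only" and "open" are said of these compounds alone.

Of the compounds shown here, three that share one core have been measured in an assay on isolated protein for inhibition of serine/threonine-protein kinase TNNI3K (Homo sapiens); on this read-out higher numbers stand for weaker inhibition and lower numbers for stronger inhibition. Compound 1 `CNc1cc(Oc2ccc(NC(=O)Nc3cccc(CF)c3)cc2)ncn1` gives 400 nM. Compound 2 `CNc1cc(Oc2ccc(NC(=O)Nc3cccc(C(F)(F)F)c3)cc2)ncn1` gives 40 nM. Compound 3 `CNc1cc(Oc2ccc(NC(=O)Nc3cccc(C(F)(F)F)c3)c(F)c2)ncn1` gives 63 nM. Going by the values given here, of these three numbers compound 2 has the lowest, but only one of its neighbours is clearly separated from it: the step of a 10-fold lower number from compound 1 to compound 2 (1.00 log units; beyond the scatter) lies beyond the scatter, whereas the step of a 1.6-fold higher number from compound 2 to compound 3 (0.20 log units; within the scatter) does not, so compound 2 and compound 3 cannot be told apart on this read-out.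

Compound 4 `CC(C)CNc1cc(Oc2ccc(NC(=O)Nc3cccc(C(F)(F)F)c3)cc2)ncn1` has not yet been measured. It differs from compound 2 in a single place: isopropyl in place of hydrogen on a saturated chain carbon bound to a nitrogen on an aromatic ring. Neither of the two measured steps touches this part of the molecule; both change groups elsewhere on the shared core. The data therefore give no direct guide to what a larger alkyl group on the amine will do, and the honest expectation is a step of no clear size in either direction. Compound 4 is thus expected to give about 60 nM in this assay, with a range from 20 nM to 200 nM, which corresponds to an expected step of a 1.5-fold higher number from compound 2 to compound 4 (0.18 log units; within the scatter).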

Compound 4, half-maximal inhibitory concentration: 50 nM
Estimate against measurement, compound 4: 1.2-fold (0.08 log units) above, and the stated range covers the measured number.
By their numbers in this assay, from the lowest: compounds 2, 4 and 3 (each within the scatter of the next); then compound 1.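

Changing methylamino to isobutylamino gives a 1.3-fold higher number from compound 2 to compound 4 (0.10 log units; within the scatter) in this assay, so this read-out does not separate the two compounds. The position on the saturated chain carbon bound to a nitrogen on an aromatic ring therefore takes an isopropyl group, with its 3 heavy atoms, without a step beyond the scatter, whereas the fluoromethyl to trifluoromethyl change elsewhere on the shared core gives a 10-fold lower number from compound 1 to compound 2 (1.00 log units; beyond the scatter) and is clearly resolved. The data offer no measured explanation for this result.

Going by these compounds, what remains open is how far this holds for other groups on the same amine: one small branched chain says little about a longer chain, a cyclohexyl ring, or a chain ending in a carboxylic acid or a second amine. Also open is whether isobutylamino would give a similar result on the fluoromethyl core of compound 1 or the fluoro-bearing core of compound 3, as the only step at this position shown here starts from compound 2.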